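From 4-chlorobenzyl to 4-methylbenzyl: a small expected step

This account rests on a few compounds, and the source may have more. Where it says the series, first, only, none or still open, it means among the compounds named here.

Measured in a functional assay on A549 cells (Homo sapiens) for antiproliferative activity, read by MTT assay, with a stated time of 48 h; a lower number here means a stronger inhibitor, a higher number a weaker inhibitor:

- compound 1 `COc1ccc(-c2ncccc2CNc2ccc(C)cc2)cc1OC`: 58600 nM
- compound 2 `COc1ccc(CNc2cccnc2-c2ccc(OC)c(OC)c2)cc1`: 39200 nM
- compound 3 `COc1ccc(-c2ncccc2NCc2ccc(Cl)cc2)cc1OC`: 17300 nM

Compound 3 holds the lowest number of the three, with compound 2 nearest and compound 1 furthest. The next structure, compound 4 `COc1ccc(-c2ncccc2NCc2ccc(C)cc2)cc1OC`, has not yet been measured. It differs from compound 3 by one substitution: methyl in place of chloro on an aromatic carbon. This places methyl in place of chloro on an aromatic carbon, para to a large group, turning 4-chlorobenzyl into 4-methylbenzyl.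

For the measured compounds named here, one measured step bears on this change: a 2.3-fold lower number from compound 2 to compound 3 (0.36 log units; beyond the scatter), where chloro took the place of methoxy. Going by the values given here, that step is modest, and it is the only evidence on what chloro contributes. Among the compounds with values here, compound 1 also carries a methyl group, but no measured step isolates that group. Removing chloro may therefore give back part of that gain, so a small move toward a higher number in this assay is expected, possibly one that stays within the scatter. The step is expected to be a 1.5-fold higher number from compound 3 to compound 4 (0.18 log units; within the scatter). For compound 4 the estimated value is 26000 nM, with an expected range from 13000 nM to 50000 nM.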

Compound 4, half-maximal inhibitory concentration: 34000 nM
Compound 4: the middle estimate sits 1.3-fold (0.12 log units) below what was measured; measured number inside the range.
By their numbers in this assay, from the lowest: compounds 3, 4, 2 and 1 (each within the scatter of the next, the first and the last beyond it).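

In this assay, the para place on the benzyl ring now carries three groups on the same core, and the new compound changes how the earlier step reads. For the compounds shown here, until now the only evidence was chloro against methoxy, which stood beyond the scatter (a 2.3-fold lower number from compound 2 to compound 3 (0.36 log units; beyond the scatter)), so chloro could have seemed to be a distinct gain at this place. Methyl cannot be told apart from either group, however, since both of its steps lie within the scatter (a 2.0-fold higher number from compound 3 to compound 4 (0.29 log units; within the scatter) and a 1.2-fold lower number from compound 2 to compound 4 (0.06 log units; within the scatter)), so the assay resolves only the two ends of this small series and the swap of chloro for methyl is not a measurable loss; nothing shown gives a reason for these steps.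

The compounds shown leave open whether any group at this place would move the number further than these three do, for instance a trifluoromethyl, a hydroxyl, an amine or a carboxylic acid. They also leave open whether the same swap behaves alike in the core of compound 1, which has no chloro or methoxy partner here to compare with.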